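This account rests on a few compounds, and the source may have more. Where it says the series, first, only, none or still open, it means among the compounds named here.

Working notes on the series.

Compound 1 `CC1CCCCN1C(=S)SCc1ccc(C(=O)Nc2ccccc2N)cc1` gives 1300 nM in a functional assay on NCI-H1299 cells (Homo sapiens) for antiproliferative activity, read by CCK-8 assay, with a stated time of 72 h; on this read-out lower numbers stand for stronger inhibition and higher numbers for weaker inhibition. Compound 2 `Nc1ccccc1NC(=O)c1ccc(CSC(=S)N2CCc3cc(Cl)ccc32)cc1` gives 3280 nM in this assay. Going by the values given here, the one step so far, a 2.5-fold higher number from compound 1 to compound 2 (0.40 log units; beyond the scatter), follows the exchange of 5-chloro-2,3-dihydro-1H-indol-1-yl for 2-methylpiperidin-1-yl on the thiocarbonyl carbon. Among the compounds with values here, on the two numbers in hand compound 2 therefore stands with the highest number, compound 1 being its only neighbour.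

Compound 3 `COC(=O)c1ccc2c(c1)CCN2C(=S)SCc1ccc(C(=O)Nc2ccccc2N)cc1` keeps the whole core of compound 2 and changes only the substituent on the fused ring: methoxycarbonyl in place of chloro on an aromatic carbon. Within the data shown here, no measured step in this assay bears directly on such an exchange; the single step known concerns the amine attached to the thiocarbonyl carbon and was modest in size. The replacement of chloro by methoxycarbonyl is thus without precedent here, and no reason to expect a step beyond the scatter is available from the data.

Compound 3 is accordingly expected to show a 1.1-fold lower number from compound 2 to compound 3 (0.04 log units; within the scatter), an estimate of 3000 nM with a range from 1200 nM to 7500 nM.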

Compound 3, half-maximal inhibitory concentration: 2020 nM
Compound 3: middle estimate off by 1.5-fold (0.17 log units), on the high side, and the stated range covers the measured number.
By their numbers in this assay, from the lowest: compounds 1, 3 and 2 (each within the scatter of the next, the first and the last beyond it).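

In this assay, going by these compounds alone, the earlier step concerned only the amine on the thiocarbonyl carbon, whereas this exchange gives the first reading of a substituent on the six-membered aromatic ring of the fused system: methoxycarbonyl in place of chloro gives a 1.6-fold lower number from compound 2 to compound 3 (0.21 log units; within the scatter) and so stays within the scatter. At this place, then, a group of 4 heavy atoms with 2 hydrogen-bond acceptors stands in for a single chlorine without a difference that can be told from the scatter, so this pair gives no sign that the read-out depends on which of the two groups is present. Nothing at hand accounts for this outcome or shows what either group contributes at this position.

Only these two groups have been compared at this place, so the pair does not show how far the tolerance extends. On these data alone, it remains open whether a carboxylic acid, an amine or a longer chain on the ester at the same aromatic carbon would stay within the scatter of compound 2 or move beyond it.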